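The compounds below may be only part of what the source reports. "The series", "measured", "known", "first", "only" and "open" are said of these compounds alone.

Measured so far:
Compound 1 `COc1ccc2cc([C@H](C)c3nnc(SCc4c(C)cc(C)cc4C)n3-c3cccc(Cl)c3)ccc2c1`: 93300 nM
Compound 2 `COc1ccc2cc([C@H](C)c3nnc(SCc4ccc(C)cc4)n3-c3ccc(F)cc3)ccc2c1`: 44300 nM

Both numbers come from a functional assay on DU-145 cells (Homo sapiens) for cytotoxicity, read by MTT assay; on this read-out lower numbers stand for stronger inhibition and higher numbers for weaker inhibition. Compound 1 has the higher number of the pair, and compound 2 sits lower by a gap just beyond the usual scatter of repeated measurements. Compound 1 is therefore the weaker of the two in this test.

The next compound to be tested is compound 3 `COc1ccc2cc([C@H](C)c3nnc(SCc4c(Cl)cccc4Cl)n3-c3cccc(Cl)c3)ccc2c1`. It keeps the core of compound 1 and changes one group: 2,6-dichlorophenyl in place of 2,4,6-trimethylphenyl on a saturated chain carbon bound to a sulfur. Among the compounds with values here, the two measured compounds differ in more than one place, so no measured pair shows this swap alone, and the forecast rests on thin evidence.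

With compound 1 at 93300 nM as the starting point and compound 2 at 44300 nM as the only other reference, only a small change is expected in this assay. The estimated 1.6-fold lower number from compound 1 to compound 3 (0.19 log units; within the scatter) points slightly downward and may stay within the scatter. For compound 3 the expected value is 60000 nM, with an estimated range from 25000 nM to 130000 nM.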

Compound 3, half-maximal inhibitory concentration: <= 400000 nM
Compound 3 ended at the assay's limit; the forecaster's own chance of this, stated with the estimate: 15%; the middle value does not contradict the limit.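

In this assay compound 3 gives <= 400000 nM, which is a limit of the assay and not a number. The change from compound 1 to compound 3 therefore yields no readable step: the limit of <= 400000 nM in this assay, at which 1 of the 3 values shown sits.

As far as these compounds go, whether 2,6-dichlorophenyl in place of 2,4,6-trimethylphenyl raises or lowers the number in this assay stays open.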